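Replacing a Six-Atom Group on an Aromatic Carbon

The source may report more compounds than this note shows. Statements on the series, on what has been measured and on what is new or still open speak of the compounds shown alone.

Compound 1 `CC(C)/C(=N\O)c1ccc(Sc2cc(F)cc(C3CCOCC3)c2)cc1` and compound 2 `COC1(c2cc(F)cc(Sc3ccc4c(c3)CC/C4=N\O)c2)CCOCC1` were both tested in a functional assay (blood) for inhibition, with Homo sapiens as the target; on this read-out higher numbers stand for weaker inhibition and lower numbers for stronger inhibition. Compound 1 gives 300 nM, the highest of the two numbers, and compound 2 gives 290 nM; the two values lie within the scatter of each other, so neither can be called the stronger inhibitor. For the measured compounds named here, no step between measured compounds that differ in one place is available. Compound 3 `C/C(=N\OC(=O)C(C)(C)C)c1ccc(Sc2cc(F)cc(C3CCOCC3)c2)cc1` has not been measured. It differs from compound 1 in one place: a group of 10 heavy atoms (7 carbon, 1 nitrogen, 2 oxygen; no ring) in place of a group of 6 heavy atoms (4 carbon, 1 nitrogen, 1 oxygen; no ring), on an aromatic carbon. Going by the values given here, the data hold no measured step of this kind, so its size cannot be read from them. A modest move toward weaker inhibition is expected, a 1.7-fold higher number from compound 1 to compound 3 (0.22 log units; within the scatter), although a change within the scatter is also plausible. Compound 3 is therefore estimated at 500 nM, with a range from 150 nM to 2000 nM.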

Compound 3, half-maximal inhibitory concentration: 40 nM
For compound 3 the middle estimate is 13-fold (1.10 log units) above the measured one; measured number outside the range, below it.
By their numbers in this assay, from the lowest: compound 3; then compounds 2 and 1 (each within the scatter of the next).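

In this assay, the aromatic carbon para to a large group proves sensitive to this change: exchanging the group of 6 heavy atoms for the group of 10 heavy atoms gives a 7.5-fold lower number from compound 1 to compound 3 (0.88 log units; beyond the scatter) and moves compound 3 clear of both earlier compounds. The position therefore accepts the larger group, which has no hydrogen-bond donor and one more double bond outside aromatic rings, without any loss of inhibition. Nothing at hand explains this gain.

The step exchanges the whole group at once, so the compounds shown cannot tell which part of it goes with the lower number. On these data alone, how an acetyl ester or a methyl ether on the oxime oxygen would compare at this position remains open, as does whether the same exchange would carry over to the core of compound 2.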